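Swapping Benzyl for Trifluoromethylphenyl: Expected Liver-Cell Toxicity

A few compounds are considered here, and "the series" means these few. Any claim that something is new, unique, unknown or untested is made for them only; others in the source may bear on it.

Compound 1 `CN1CCN(CCNCc2cn(-c3ccc(F)cc3F)nc2Cc2ccccc2)CC1` was tested in an ADME assay on Huh-7 cells (Homo sapiens) for cytotoxicity; on this read-out lower numbers stand for higher toxicity in this test and higher numbers for lower toxicity in this test. For compound 1 the read-out is only a limit, > 20000 nM, which is the limit of > 20000 nM in this assay, at which 1 of the 2 values shown sits. Compound 2 `CN1CCN(CCCNCc2cn(-c3ccc(C(F)(F)F)cc3)nc2-c2ccc(Cl)cc2)CC1` gives 2500 nM in this assay. Compound 3 `CN1CCN(CCNCc2cn(-c3ccc(F)cc3F)nc2-c2ccc(C(F)(F)F)cc2)CC1` is compound 1 after one change: 4-(trifluoromethyl)phenyl in place of benzyl on an aromatic carbon. Because compound 2, which likewise carries an aromatic ring directly on its core, gives 2500 nM, a move toward higher toxicity seems plausible. The step of an at least 2.5-fold lower number from compound 1 to compound 3 (0.39 log units; beyond the scatter) is expected to be moderate, toward higher toxicity. Compound 3 is estimated at 8000 nM, within a range from 2500 nM to 20000 nM.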

Compound 3, half-maximal cytotoxic concentration: 20000 nM
Compound 3: the middle estimate sits 2.5-fold (0.40 log units) below what was measured; the range from low to high includes it.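

With 4-(trifluoromethyl)phenyl in place of benzyl on this aromatic carbon, the read-out shows a number no higher from compound 1 to compound 3 (the limit leaves the size open) in this assay. Compound 3 gives 20000 nM, so this ring, set directly on the core, still leaves a high number on this read-out. Compound 1 gives > 20000 nM, which is a limit of the assay. The size of the change cannot be read because compound 1 stands at that limit: the limit of > 20000 nM in this assay, at which 1 of the 3 values shown sits.

From the compounds shown here alone, what stays open is how this position responds to other groups, such as a pyridine ring or a carboxylic acid. A group of either kind in this place could move the number either way.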